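From (2-methoxyphenyl)amino to dipropylamino on a shared core

The source may hold more compounds than are shown below. What is called first, only, known or untested is meant among the compounds shown, and "the series" means these compounds.

Of the compounds shown here, two built on one core have been tested in a functional assay on MCF7 cells (Homo sapiens) for inhibition, read by sulforhodamine B assay (a lower number here means a stronger inhibitor, a higher number a weaker inhibitor), so far. There, compound 1 (`O=C1C=C(NC2CCCC2)C(=O)c2c1nc1n2[C@H]2OC[C@@H](O)[C@H]2OC1`) gives > 16000 nM as its result, which is a limit and not a number. Compound 2 (`COc1ccccc1NC1=CC(=O)c2nc3n(c2C1=O)[C@H]1OC[C@@H](O)[C@H]1OC3`) gives > 4000 nM as its result, and this too is only a limit. Within the data shown here, compound 2 therefore has no exact place on the scale, and the one other value beside it is also a limit.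

The next compound is compound 3 (`CCCN(CCC)C1=CC(=O)c2nc3n(c2C1=O)[C@H]1OC[C@@H](O)[C@H]1OC3`), and the change is dipropylamino in place of (2-methoxyphenyl)amino on a double-bonded ring carbon in one swap: dipropylamino in place of (2-methoxyphenyl)amino on a double-bonded ring carbon. Among the measured compounds shown here, the only measured step, a step that the two limits leave unreadable from compound 1 to compound 2 in size, replaces cyclopentyl with 2-methoxyphenyl on an amine nitrogen and offers no size to carry over. The expectation therefore rests on compound 2 at > 4000 nM as a limit. In this assay no clear direction is expected, and the estimated change is a step that the limit leaves unreadable from compound 2 to compound 3 for this swap. The estimate for compound 3 is 8000 nM with an expected range from 2000 nM to 30000 nM in this assay.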

Compound 3, half-maximal inhibitory concentration: > 16000 nM
Compound 3 ended at the assay's limit; the forecaster's own chance of this, stated with the estimate: 60%; middle value at least 2.0-fold (0.30 log units) from the limit.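

In this assay compound 3 gives > 16000 nM, which is a limit and not a number. Compound 1 and compound 2 also stand at limits, and no size can be read for the step to compound 3 from either of them. The compounds shown leave open how strongly each inhibits and whether changing the amine group on the shared core alters this at all.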